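A few compounds are considered here, and "the series" means these few. Any claim that something is new, unique, unknown or untested is made for them only; others in the source may bear on it.

In a functional assay on HOP-62 cells (Homo sapiens) for cytotoxicity, read by resazurin assay, with a stated time of 72 h (on this read-out higher numbers stand for weaker inhibition and lower numbers for stronger inhibition), compound 1 (`O=C(/C=C/c1ccc(OCCCCCO[N+](=O)[O-])c(O)c1)OCCCCCO[N+](=O)[O-]`) gives > 50000 nM, which is a limit of the assay and not a number. That puts compound 1 at the limit of > 50000 nM in this assay, at which 1 of the 3 values shown sits. Two other compounds return actual numbers: compound 2 (`O=C(/C=C/c1ccc(O)c(O)c1)OCc1c(-c2ccccc2)no[n+]1[O-]`) gives 6120 nM and compound 3 (`COc1cc(/C=C/C(=O)Oc2ccc(OCc3c(-c4ccccc4)no[n+]3[O-])cc2)ccc1O`) gives 30400 nM.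

Compound 4 (`COc1cc(/C=C/C(=O)OCCCCCO[N+](=O)[O-])ccc1OCCCCCO[N+](=O)[O-]`) has not yet been measured. It differs from compound 1 by a single edit, methyl in place of hydrogen on an oxygen on an aromatic ring, which turns a hydroxy into a methoxy. For the measured compounds named here, no pair of measured compounds shows this change on its own, which makes any forecast uncertain.

The expected step in this assay is none beyond the scatter, in either direction, and this expectation rests on the limit of compound 1 at > 50000 nM. In numbers, the estimate is a number no higher from compound 1 to compound 4 (the limit leaves the size open), and the assay may again report only a limit. Compound 4 is estimated at 50000 nM, with an expected range from 20000 nM to 100000 nM.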

Compound 4, half-maximal inhibitory concentration: > 50000 nM
Compound 4 gave a limit, no number; the forecaster's own chance of this, stated with the estimate: 70%; the middle value lies on the limit itself.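

Compound 1 and compound 4 both return a limit of the assay rather than a number, so no step can be read between them in this assay: the limit of > 50000 nM in this assay, at which 2 of the 4 values shown sit. The compounds shown leave open what turning a hydroxy into a methoxy does on its own, as no pair with actual numbers shows that change.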